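A few compounds are considered here, and "the series" means these few. Any claim that something is new, unique, unknown or untested is made for them only; others in the source may bear on it.

Compound 1 `CCCCCCc1nc(C(F)(F)F)ccc1CNC(=O)C(C)c1ccc(NS(C)(=O)=O)c(F)c1`: in an assay on CHO cells for antagonist activity at transient receptor potential cation channel subfamily V member 1 (Homo sapiens), read by FLIPR and calcium flux (on this read-out higher numbers stand for weaker inhibition and lower numbers for stronger inhibition), compound 1 gives 1.6 nM.
Compound 2 `CC(C(=O)NCc1ccc(C(F)(F)F)nc1C1CCC(F)(F)CC1)c1ccc(NS(C)(=O)=O)c(F)c1`: in this assay compound 2 gives 1.5 nM.
Compound 3 `CC(C(=O)NCc1ccc(C(F)(F)F)nc1C1CC2CCC1C2)c1ccc(NS(C)(=O)=O)c(F)c1`: in this assay compound 3 gives 1.5 nM.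

Compound 3 stands level with compound 2, the two together the lowest of the three numbers, and all three sit within the scatter of one another. Compound 4 `CC(C(=O)NCc1ccc(C(F)(F)F)nc1C1=CCC(C)(C)CC1)c1ccc(NS(C)(=O)=O)c(F)c1` differs from compound 3 by a group of 8 heavy atoms (8 carbon; one six-membered non-aromatic ring of carbon only) in place of a group of 7 heavy atoms (7 carbon; 2 five-membered non-aromatic rings of carbon only), on an aromatic carbon. This position has been varied twice already: a 1.1-fold lower number from compound 1 to compound 3 (0.03 log units; within the scatter) and no change at the digits printed from compound 2 to compound 3 (within the scatter). Neither involves the group that now enters, but each change made there has left the number essentially where it was. The step to compound 4 is therefore expected to be a 1.1-fold higher number from compound 3 to compound 4 (0.03 log units; within the scatter), no change beyond the scatter. Compound 4 is estimated to give 1.6 nM, within a range of 0.6 nM to 4 nM.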

Compound 4, inhibition constant: 0.2 nM
For compound 4 the middle estimate is 8.0-fold (0.90 log units) above the measured one, and the stated range ends above it.
By their numbers in this assay, from the lowest: compound 4; then compounds 2, 3 and 1 (each within the scatter of the next).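

The position next to the ring nitrogen had stayed flat across hexyl, 4,4-difluorocyclohexyl and a group of two five-membered carbon rings, but in this assay 4,4-dimethylcyclohex-1-en-1-yl moves the number, with an 8.0-fold lower number from compound 1 to compound 4 (0.90 log units; beyond the scatter), a 7.5-fold lower number from compound 2 to compound 4 (0.88 log units; beyond the scatter) and a 7.5-fold lower number from compound 3 to compound 4 (0.88 log units; beyond the scatter). So this position is not indifferent to what it carries, and the entering group is the only one of the four with a double bond outside aromatic rings. Nothing available here accounts for the drop. Whether it follows the double bond or the two methyl groups stays open, since a saturated 4,4-dimethylcyclohexyl or an unsubstituted cyclohexenyl group does not appear among these compounds.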